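This account rests on a few compounds, and the source may have more. Where it says the series, first, only, none or still open, it means among the compounds named here.

Of the compounds shown here, three have been measured in an ADME assay on HepG2 cells (Homo sapiens) for cytotoxicity, read by luminescence, with a stated time of 72 h; on this read-out lower numbers stand for an effect already at smaller amounts and higher numbers for an effect only at larger amounts of compound.
Compound 1, `CCOC(=O)c1c(-c2cccc(OC)c2)[nH]c2cc(OC)ccc2c1=O`, gives > 21500 nM, which is a limit of the assay rather than a number.
Compound 2, `CCOC(=O)c1c(-c2cccc(OC)c2)[nH]c2cc(OC(F)(F)F)ccc2c1=O`, gives > 21500 nM, also only a limit.
Compound 3, `CCOC(=O)c1c(-c2cccc(OC)c2)[nH]c2cc(C(F)(F)F)ccc2c1=O`, gives > 21500 nM, again only a limit.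

Compound 4, `CCOC(=O)c1c(-c2cccc(OC(F)(F)F)c2)[nH]c2cc(C(F)(F)F)ccc2c1=O`, has not yet been measured. It differs from compound 3 by trifluoromethyl in place of methyl on an oxygen on an aromatic ring. The same change was made from compound 1 to compound 2, where the step was a step that the two limits leave unreadable from compound 1 to compound 2, since all three values sit at the limit of > 21500 nM in this assay, at which 3 of the 3 values shown sit. The cores of the two pairs differ by trifluoromethyl in place of methoxy on an aromatic carbon; the place of the change reads the same in both pairs, so it counts as the same change. The step from compound 3 to compound 4 is expected to be a step that the limit leaves unreadable from compound 3 to compound 4, resting on a step that the two limits leave unreadable from compound 1 to compound 2 and on (the limit of > 21500 nM in this assay, at which 3 of the 3 values shown sit). Compound 4 is therefore estimated at 30000 nM, most likely again reported only as a limit.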

Compound 4, half-maximal effective concentration: > 21500 nM
Compound 4: only a limit was reported; the forecaster's own chance of this, stated with the estimate: 85%; the middle value lies beyond the limit too.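

Compound 4 and compound 3 both give only a limit, so no step can be read between them: the limit of > 21500 nM in this assay, at which 4 of the 4 values shown sit.

The compounds shown leave open at what concentration, if any, each would show an effect in this assay.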